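Dichlorophenyl for methoxyphenyl on the ring nitrogen

The source may report more compounds than this note shows. Statements on the series, on what has been measured and on what is new or still open speak of the compounds shown alone.

Within the data shown here, compound 2 `COc1ccccc1N1CCN(CCCCn2cc(-c3ccc(-c4ccccc4)cc3)nn2)CC1` is the only member of the set that gives a number in an assay on HEK293 cells for displacement of a labelled ligand from D(4) dopamine receptor (Homo sapiens), read by scintillation counting, with a stated time of 1 h (a higher number here means a weaker inhibitor, a lower number a stronger inhibitor), where compound 2 gives 425 nM. Compound 1 `OC(CCn1cc(-c2ccc(-c3ccccc3)cc2)nn1)CN1CCN(c2cccc(Cl)c2Cl)CC1` returns only a limit, > 7000 nM, which is the limit of > 7000 nM in this assay, at which 1 of the 3 values shown sits. Compound 3 `COc1ccccc1N1CCN(CC(O)CCn2cc(-c3ccc4ccccc4c3)nn2)CC1` likewise returns only a limit, > 2000 nM, which is the limit of > 2000 nM in this assay, at which 1 of the 3 values shown sits. Among the measured compounds shown here, neither of those two compounds differs from compound 2 in a single place, so no measured step is available for comparison.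

Compound 4 `Clc1cccc(N2CCN(CCCCn3cc(-c4ccc(-c5ccccc5)cc4)nn3)CC2)c1Cl` differs from compound 2 in one place: 2,3-dichlorophenyl in place of 2-methoxyphenyl on an amine nitrogen in a ring. Nothing measured here shows how this change alone shifts affinity; compound 1 carries the same 2,3-dichlorophenyl on an amine nitrogen in a ring but also differs from compound 2 elsewhere, so its limit cannot be read as the effect of the swap by itself. The step is expected to be a 1.2-fold lower number from compound 2 to compound 4 (0.08 log units; within the scatter), no larger than the usual scatter in either direction. Compound 4 is accordingly expected to give 350 nM in this assay, with a range of 60 nM to 2000 nM.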

Compound 4, inhibition constant: > 10000 nM
Compound 4 gave a limit, no number; the forecaster's own chance of this, stated with the estimate: 10%; middle value at least 28-fold (1.45 log units) from the limit.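

Among these compounds, on an amine nitrogen in a ring, 2,3-dichlorophenyl in place of 2-methoxyphenyl gives the first readable step in this assay: an at least 23-fold higher number from compound 2 to compound 4 (1.37 log units; beyond the scatter). Compound 4 gives only a limit, so this size is a lower bound and the true step may be larger. On this core, the change at this position is therefore not neutral, and nothing measured here gives a cause for the step.

From the compounds shown here alone, the step from compound 1 to compound 4 cannot be read because both values are limits, so the effect of the hydroxy on the chain remains open with 2,3-dichlorophenyl in place. Also open, going by these compounds, is whether a plain phenyl, 2-chlorophenyl or 3-chlorophenyl at this position would keep a measurable number.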